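This account rests on a few compounds, and the source may have more. Where it says the series, first, only, none or still open, it means among the compounds named here.

Measured compounds:
- compound 1, `CC(C)CN(CC(C)C)c1ccc(/C(=N/O)Nc2ccc(F)c(Br)c2)cc1NC(=O)Nc1ccc(Cl)cc1`, in an assay on HeLa cells for inhibition of Indoleamine 2,3-dioxygenase 1 (Homo sapiens) (a higher number here means a weaker inhibitor, a lower number a stronger inhibitor), compound 1 gives 440 nM
- compound 2, `CCCNC(=O)Nc1cc(/C(=N/O)Nc2ccc(F)c(Br)c2)ccc1N(CC(C)C)CC(C)C`, in this assay compound 2 gives 2610 nM

Compound 2 stands at the higher of these two numbers, the weaker inhibitor of the pair; the single step shown, a 5.9-fold higher number from compound 1 to compound 2 (0.77 log units; beyond the scatter), put it there. Compound 3, `Cc1ccc(NC(=O)Nc2cc(/C(=N/O)Nc3ccc(F)c(Br)c3)ccc2N(CC(C)C)CC(C)C)cc1`, differs from compound 2 by 4-methylphenyl in place of propyl on an amide-type nitrogen. This change largely reverses the step from compound 1 to compound 2, restoring a substituted phenyl on that nitrogen, now carrying methyl rather than chloro. Among the measured compounds shown here, that one step, a modest change beyond the scatter, is the only guide available, so in this assay compound 3 is expected to return toward the number of compound 1, with a step of roughly the same size in the opposite direction, though the different ring substituent leaves the exact size uncertain. Compound 3 is therefore estimated at 600 nM, expected between 250 nM and 1500 nM, a step of a 4.4-fold lower number from compound 2 to compound 3 (0.64 log units; beyond the scatter).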

Compound 3, half-maximal inhibitory concentration: 760 nM
Estimate against measurement, compound 3: 1.3-fold (0.10 log units) below; the measured number falls inside the stated range.
By their numbers in this assay, from the lowest: compounds 1 and 3 (each within the scatter of the next); then compound 2.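

In this assay, 4-methylphenyl in place of propyl on the amide-type nitrogen gives a 3.4-fold lower number from compound 2 to compound 3 (0.54 log units; beyond the scatter), so among these three compounds both of those carrying a substituted phenyl ring there have lower numbers than the one carrying propyl. Methyl in place of chloro on an aromatic carbon gives a 1.7-fold higher number from compound 1 to compound 3 (0.24 log units; within the scatter), which lies within the scatter, so this assay does not separate these two ring substituents. No measurement at hand speaks to the reason for either step.

Only propyl, 4-methylphenyl and the chlorinated phenyl ring of compound 1 are shown on this nitrogen, so it remains open how a longer chain such as hexyl, or a benzyl group, would compare. Going by these compounds, it is also open whether a methoxy group or a carboxylic acid on the ring would behave like methyl and chloro.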